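A few compounds are considered here, and "the series" means these few. Any claim that something is new, unique, unknown or untested is made for them only; others in the source may bear on it.

Measured in an in vitro ADME assay on microsomes from liver (Homo sapiens) for pharmacokinetics, read by LC-MS, with a stated time of 10 min, tested at 1 uM; on this read-out lower numbers stand for slow clearance and higher numbers for fast clearance:
compound 1 `CN1C[C@H](C(=O)Nc2ccccc2)[C@@H](c2ccc(/C=C/C(=O)Nc3ccccc3N)cc2)C1`: 7 mL/min/kg
compound 2 `CN1C[C@H](C(=O)Nc2ccc(Br)cc2)[C@@H](c2ccc(/C=C/C(=O)Nc3ccccc3N)cc2)C1`: 3 mL/min/kg
compound 3 `CN1C[C@H](C(=O)Nc2ccc(Cl)c(Cl)c2)[C@@H](c2ccc(/C=C/C(=O)Nc3ccccc3N)cc2)C1`: 14 mL/min/kg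

Compound 3 reads 14 mL/min/kg. Its nearest measured neighbour gives a 2.0-fold higher number from compound 1 to compound 3 (0.30 log units; within the scatter), and its furthest gives a 4.7-fold higher number from compound 2 to compound 3 (0.67 log units; beyond the scatter).

Compound 4 `CN1C[C@H](C(=O)Nc2ccc(Cl)cc2F)[C@@H](c2ccc(/C=C/C(=O)Nc3ccccc3N)cc2)C1` comes from compound 3 by a single change: 4-chloro-2-fluorophenyl in place of 3,4-dichlorophenyl on an amide-type nitrogen. This is 4-chloro-2-fluorophenyl in place of 3,4-dichlorophenyl on an amide-type nitrogen. Going by the values given here, the entering group has no measured precedent, so no step carries over directly. The nearest evidence is the set of changes at this same group. One is a 2.3-fold lower number from compound 1 to compound 2 (0.37 log units; beyond the scatter), and the others are the two steps into compound 3 given above. These steps are small to modest and run in both directions. A step of modest size at most is therefore expected in this assay, leaning to a lower number because of a 4.7-fold higher number from compound 2 to compound 3 (0.67 log units; beyond the scatter). The expected change is a 1.8-fold lower number from compound 3 to compound 4 (0.24 log units; within the scatter). For compound 4 the estimated value is 8 mL/min/kg, with an expected range of 3 mL/min/kg to 18 mL/min/kg.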

Compound 4, clearance: 11 mL/min/kg
Beside the measured number, compound 4's estimate is 1.4-fold (0.14 log units) below it; measured number inside the range.
By their numbers in this assay, from the lowest: compound 2; then compounds 1, 4 and 3 (each within the scatter of the next).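

In this assay, swapping 3,4-dichlorophenyl for 4-chloro-2-fluorophenyl on the amide-type nitrogen leaves the clearance level (a 1.3-fold lower number from compound 3 to compound 4 (0.10 log units; within the scatter)), and the entering group also stays level with plain phenyl (a 1.6-fold higher number from compound 1 to compound 4 (0.20 log units; within the scatter)). Among the four aryl groups, only 4-bromophenyl stands apart (a 3.7-fold higher number from compound 2 to compound 4 (0.56 log units; beyond the scatter)), so compound 2 is now separated beyond the scatter from both chlorine-bearing compounds, while compound 1 is not separated from either. Nothing measured here bears on what sets compound 2 apart.

The compounds shown leave open whether a ring carrying chlorine alone would read like compound 2 or like compound 4. As far as these compounds go, how an amine or a carboxylic acid on this ring would read in this assay is also open.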